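The compounds below may be only part of what the source reports. "The series", "measured", "known", "first", "only" and "open" are said of these compounds alone.

Working notes on the series in a functional assay on HEK-EM293 cells for agonist activity at Thyrotropin receptor (Homo sapiens), read by ELISA and cAMP accumulation, with a stated time of 1 h; on this read-out lower numbers stand for smaller maximal responses and higher numbers for larger maximal responses.

Compound 1, `COc1ccc(C2Nc3cccc(OC)c3C(=O)N2Cc2ccccc2)cc1COc1ccc(NC(C)=O)cc1`, is the weaker of the two measured compounds on this read-out: in this assay compound 1 gives 49.1%. Compound 2, `COc1ccc(C2Nc3ccc(O)cc3C(=O)N2Cc2ccccc2)cc1COc1ccc(NC(C)=O)cc1`, reaches a markedly larger maximal response in this assay, where compound 2 gives 93.3%; the difference lies beyond the usual scatter. Compound 2 differs from compound 1 in more than one place, so the two values are noted side by side without ascribing the gap to either change.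

Compound 3, `COc1ccc(C2Nc3cccc(F)c3C(=O)N2Cc2ccccc2)cc1COc1ccc(NC(C)=O)cc1`, has not yet been measured in this assay. It differs from compound 1 in one place only: fluoro in place of methoxy on an aromatic carbon.

Within the data shown here, no measured pair isolates this change, so the expectation rests on compound 1 alone. The step from compound 1 to compound 3 in this assay is expected to be small, a number 2.9 percentage points higher from compound 1 to compound 3 (within the scatter), not clearly beyond the scatter in either direction. Compound 3 is accordingly estimated to give about 52% in this assay, with a range from 30% to 80%.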

Compound 3, largest response reached (Emax), in percent of the reference or control that the assay uses: 94.7%
Beside the measured number, compound 3's estimate is 42.7 percentage points below it; measured number outside the range, above it.
By their numbers in this assay, from the lowest: compound 1; then compounds 2 and 3 (each within the scatter of the next).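

Fluoro in place of methoxy on this aromatic carbon, ortho to a fused ring, gives in this assay a number 45.6 percentage points higher from compound 1 to compound 3 (beyond the scatter) and is the first change in the series that can be read at a single place. The maximal response therefore depends strongly on the group at this one position, which the two earlier compounds could not show, as they differ in more than one place. The change swaps a methoxy of two heavy atoms and one hydrogen-bond acceptor for a fluoro of one heavy atom and no acceptor, but no measurement on hand says which of these differences matters or explains the step.

Still open, as far as these compounds go, is whether the step belongs to fluoro itself or to the loss of methoxy, a question that plain hydrogen, chloro or an amine on the same carbon would help to settle. Equally open, from the compounds shown here alone, is whether a longer alkoxy chain at this position would lower the maximal response further, and whether the fluoro effect holds when the benzyl group or the acetamide side of the core changes.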